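Swapping the hydroxy for an aminothiadiazolyl sulfanyl group

The source may report more compounds than this note shows. Statements on the series, on what has been measured and on what is new or still open speak of the compounds shown alone.

Compound 1 `CC1(C)O[C@H]2[C@H](OCc3noc(-c4ccc([N+](=O)[O-])cc4)n3)O[C@H](CSc3ncn[nH]3)[C@H]2O1`: in a functional assay on T47D cells (Homo sapiens) for antiproliferative activity, read by sulforhodamine B assay, with a stated time of 48 h (on this read-out lower numbers stand for stronger inhibition of growth and higher numbers for weaker inhibition of growth), compound 1 gives > 100000 nM, a limit of the assay.
Compound 2 `CC1(C)O[C@H]2[C@H](OCc3noc(-c4ccc([N+](=O)[O-])cc4)n3)O[C@H](CO)[C@H]2O1`: in this assay compound 2 gives > 100000 nM, also a limit.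

Compound 2 therefore stands at the limit described by the limit of > 100000 nM in this assay, at which 2 of the 2 values shown sit, and the step that the two limits leave unreadable from compound 1 to compound 2 cannot be read. Compound 3 `CC1(C)O[C@H]2[C@H](OCc3noc(-c4ccc([N+](=O)[O-])cc4)n3)O[C@H](CSc3nnc(N)s3)[C@H]2O1` differs from compound 2 by (5-amino-1,3,4-thiadiazol-2-yl)sulfanyl in place of hydroxy on a saturated chain carbon bound to a saturated ring carbon. Going by the values given here, the single measured step is unreadable, so no direction can be drawn from it; compound 1, which carries a sulfanyl-linked ring of its own, also sat at the limit. For compound 3 the expected step that the limit leaves unreadable from compound 2 to compound 3 is not beyond the scatter. The estimate for compound 3 is 150000 nM, ranging 50000 nM to 500000 nM, most likely again only a limit.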

Compound 3, concentration for 50% growth inhibition: > 100000 nM
Compound 3 was reported as a limit; the forecaster's own chance of this, stated with the estimate: 85%; the middle value is on the limit's open side.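

Going by these compounds alone, compound 3 gives > 100000 nM in this assay, which is a limit, so no step among compound 1, compound 2 and compound 3 can be read. Whether these three groups differ at all in their effect on growth stays open, as every value sits at the same limit: the limit of > 100000 nM in this assay, at which 3 of the 3 values shown sit.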